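A few compounds are considered here, and "the series" means these few. Any claim that something is new, unique, unknown or untested is made for them only; others in the source may bear on it.

Working notes on the series.

Compound 1 `Nc1ccccc1NC(=O)c1ccc(CSC(=S)N2CCN(Cc3cccnc3)CC2)cc1` gives 89.2% in a functional assay on A-375 cells (Homo sapiens) for antiproliferative activity, read by CCK-8 assay, with a stated time of 72 h, tested at 8 uM; on this read-out higher numbers stand for a stronger effect at the one concentration tested and lower numbers for a weaker effect. Compound 2 `CN1CCN(C(=S)SCc2ccc(C(=O)Nc3ccccc3N)cc2)CC1` gives 91.6% in this assay; compound 2 carries the higher of the two numbers, but the step of a number 2.4 percentage points higher from compound 1 to compound 2 (within the scatter) stays within the scatter, so the two compounds cannot be told apart on this read-out and neither can be called the stronger.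

Compound 3 `Cc1ccc(N2CCN(C(=S)SCc3ccc(C(=O)Nc4ccccc4N)cc3)CC2)cc1` is not yet measured. It differs from compound 2 by 4-methylphenyl in place of methyl on an amine nitrogen in a ring. Among the measured compounds shown here, the only step so far that touches this position is the one from compound 1 to compound 2, where a hydrogen replaced a pyridin-3-yl on the saturated chain carbon bound to the ring nitrogen and the number moved a number 2.4 percentage points higher from compound 1 to compound 2 (within the scatter), within the scatter. A group of a different kind now enters at the ring nitrogen itself, so that step bears only loosely on the present one. With no step beyond the scatter anywhere in the series, no change beyond the scatter is expected in this assay; the expected step is a number 3.6 percentage points lower from compound 2 to compound 3 (within the scatter). Compound 3 is therefore estimated to give 88% in this assay, with a range from 74% to 96%.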

Compound 3, a percentage reported as inhibition, at one concentration (the size of the read-out at that concentration, not a potency): 26.4%
Compound 3: middle estimate off by 61.6 percentage points, on the high side; the measured number lies below the stated range.
By their numbers in this assay, from the lowest: compound 3; then compounds 1 and 2 (each within the scatter of the next).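

In this assay, among the compounds shown here, the step of a number 65.2 percentage points lower from compound 2 to compound 3 (beyond the scatter) is the first beyond the scatter, and it shows that the group on the amine nitrogen in the ring can decide the read-out, which the earlier pair gave no sign of. The step of a number 62.8 percentage points lower from compound 1 to compound 3 (beyond the scatter) points the same way, so methyl and (pyridin-3-yl)methyl, which could not be told apart at this position, both stand clear of 4-methylphenyl. Nothing at hand accounts for the drop.

The compounds shown leave open whether the loss belongs to an aromatic ring bound directly to the nitrogen or to the methyl group on that ring, since the aromatic ring in compound 1 sits on a chain carbon and keeps a high number; an unsubstituted phenyl or a 4-methylbenzyl group on this nitrogen would separate the two. Going by these compounds, with one concentration only, it also stays open how far compound 3 lies from compound 2 in potency.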